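The compounds below may be only part of what the source reports. "The series", "measured", "known", "first", "only" and "open" are said of these compounds alone.

For the measured compounds named here, compound 2, `Cc1cccc(-c2cc3nc(C)ccc3cn2)c1`, is the one compound in this set that stands on a number. In a functional assay on CHO cells for antagonist activity at metabotropic glutamate receptor 5 (Rattus norvegicus), read by calcium flux (a higher number here means a weaker inhibitor, a lower number a stronger inhibitor), compound 2 gives 676 nM. Compound 1, `Cc1ccc2cnc(-c3ccccc3)cc2n1`, carries a hydrogen where compound 2 carries a methyl on an aromatic carbon. In this assay compound 1 gives > 30000 nM, which is a limit of the assay and not a number, at the limit of > 30000 nM in this assay, at which 1 of the 2 values shown sits. The step of an at least 44-fold lower number from compound 1 to compound 2 (1.64 log units; beyond the scatter) shows that a group on this aromatic carbon changes the outcome strongly. Compound 3, `COc1cccc(-c2cc3nc(C)ccc3cn2)c1`, differs from compound 2 by methoxy in place of methyl on an aromatic carbon. Going by the values given here, that single measured step bears on this change only in part: it tells what a methyl does against a hydrogen, not what a methoxy does against a methyl, and no step between two substituted compounds has been measured. Compound 3 is therefore expected to keep a number in this assay, with a modest weakening, a 2.2-fold higher number from compound 2 to compound 3 (0.35 log units; beyond the scatter). The estimate for compound 3 is 1500 nM, within a range from 400 nM to 6000 nM.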

Compound 3, half-maximal inhibitory concentration: 7900 nM
For compound 3 the middle estimate is 5.3-fold (0.72 log units) below the measured one, and the stated range ends below it.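

At this carbon, meta to a large group, the identity of the group matters and not only its presence: methoxy in place of methyl gives a 12-fold higher number from compound 2 to compound 3 (1.07 log units; beyond the scatter) and so gives back much of what methyl gained over hydrogen. Methoxy still stands ahead of hydrogen, with an at least 3.7-fold lower number from compound 1 to compound 3 (0.57 log units; beyond the scatter) as the step between them. The size of that step is only a bound, because the value of compound 1 is a limit of the assay and not a number: the limit of > 30000 nM in this assay, at which 1 of the 3 values shown sits.

The compounds shown leave open whether a chlorine, a nitrile or a longer chain such as ethyl on this carbon would track methyl or methoxy. They also leave open what methyl or methoxy would do on any other carbon of that ring.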